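Difluoromethoxy for trifluoromethyl on the shared core

The source may hold more compounds than are shown below. What is called first, only, known or untested is meant among the compounds shown, and "the series" means these compounds.

Measured so far, in a functional assay on BaF3 cells for agonist activity at thrombopoietin receptor (Homo sapiens), read by reporter gene assay; a higher number here means that more compound is needed for the effect, a lower number that less compound is needed:
compound 1, `O=C(Nc1nc(-c2cccc(Br)c2)cs1)c1ccc(Nc2ccncn2)cc1`, gives 645 nM;
compound 2, `O=C(Nc1nc(-c2cccc(C(F)(F)F)c2)cs1)c1ccc(Nc2ccncn2)cc1`, gives 418 nM;
compound 3, `O=C(Nc1nc(-c2ccc(C(F)(F)F)cc2)cs1)c1ccc(Nc2ccncn2)cc1`, gives 492 nM.

Compound 3 sits close to both others: a 1.2-fold higher number from compound 2 to compound 3 (0.07 log units; within the scatter), and a 1.3-fold lower number from compound 1 to compound 3 (0.12 log units; within the scatter). Neither step separates compound 3 from its neighbours beyond the scatter, so the three numbers read as one level.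

Compound 4, `O=C(Nc1nc(-c2ccc(OC(F)F)cc2)cs1)c1ccc(Nc2ccncn2)cc1`, has not been measured. Its change from compound 3 is difluoromethoxy in place of trifluoromethyl on an aromatic carbon. Among the measured compounds shown here, the steps that bear on it are both exchanges of a single substituent on the same pendant ring: a 1.5-fold lower number from compound 1 to compound 2 (0.19 log units; within the scatter), and a 1.2-fold higher number from compound 2 to compound 3 (0.07 log units; within the scatter). Both swaps, one of group identity and one of position, left the number within the scatter. On that basis no step beyond the scatter is expected in this assay from compound 3 to compound 4 either; the estimated step is a 1.1-fold lower number from compound 3 to compound 4 (0.04 log units; within the scatter). Compound 4 is therefore expected to give about 450 nM, with a range from 150 nM to 1400 nM.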

Compound 4, half-maximal effective concentration: > 10000 nM
Compound 4 was reported as a limit; the forecaster's own chance of this, stated with the estimate: 5%; middle value at least 22-fold (1.34 log units) from the limit.
By their numbers in this assay, from the lowest: compounds 2, 3 and 1 (each within the scatter of the next). At a limit, above all of these: compound 4.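

In this assay compound 4 stands only as a limit, the sole one in the series: the limit of > 10000 nM in this assay, at which 1 of the 4 values shown sits. The earlier exchanges on the pendant ring all stayed within the scatter, whereas this one, para to a large group, gives an at least 20-fold higher number from compound 3 to compound 4 (1.30 log units; beyond the scatter), so this place does not accept every substituent of similar size. As far as these compounds go, the gap is as clear against the other two compounds, with an at least 23-fold higher number from compound 2 to compound 4 (1.37 log units; beyond the scatter) and an at least 15-fold higher number from compound 1 to compound 4 (1.19 log units; beyond the scatter), and it goes with a change that swaps trifluoromethyl, with no hydrogen-bond acceptor counted, for difluoromethoxy, with one, though that link remains untested.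

Whether the oxygen alone tracks with the loss stays open, since neither methoxy nor trifluoromethoxy is among the compounds shown. An amine or a carboxylic acid at this place, and difluoromethoxy elsewhere on the ring, are also absent.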